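Shortening one ether chain on a weak cell growth inhibitor

The source may report more compounds than this note shows. Statements on the series, on what has been measured and on what is new or still open speak of the compounds shown alone.

- Compound 1 `C=CCCCCOc1cc(F)ccc1-c1cnc(OCCC=C)n1C`: 83000 nM
- Compound 2 `C=CCCCCOc1ccccc1-c1cnc(OCCCC=C)n1C`: 19000 nM
- Compound 3 `C=CCCCCOc1cc2ccccc2cc1-c1cnc(OCCCCC=C)n1C`: 59000 nM

In a functional assay on SK-MEL-28 cells (Homo sapiens) for inhibition, read by colorimetric assay and MTT assay, with a stated time of 72 h (on this read-out lower numbers stand for stronger inhibition and higher numbers for weaker inhibition), compound 2 has the lowest number of the three at 19000 nM, which makes it the strongest inhibitor so far. Its gaps to compound 3 and compound 1 both lie beyond the usual scatter.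

Compound 4 `C=CCCCCOc1ccccc1-c1cnc(OC)n1C` has hydrogen in place of but-3-en-1-yl on a saturated chain carbon bound to an oxygen on an aromatic ring. This turns (pent-4-en-1-yl)oxy into methoxy.

Going by the values given here, no measured pair isolates this change, so the expectation stays close to compound 2 at 19000 nM. The expected step of a 1.6-fold higher number from compound 2 to compound 4 (0.20 log units; within the scatter) is a slight rise in the number, within the scatter. Compound 4 is estimated at 30000 nM, with an expected range of 9000 nM to 100000 nM.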

Compound 4, half-maximal inhibitory concentration: 85000 nM
The estimate for compound 4 lay 2.8-fold (0.45 log units) below the measured number, within the range that was stated.
By their numbers in this assay, from the lowest: compound 2; then compounds 3, 1 and 4 (each within the scatter of the next).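

In this assay the change gives a 4.5-fold higher number from compound 2 to compound 4 (0.65 log units; beyond the scatter) and so weaker inhibition. Going by these compounds alone, this is the first single-place comparison. On the core of compound 2, compound 4 has methoxy in place of (pent-4-en-1-yl)oxy and shows weaker inhibition. Nothing measured here explains why. The step alone cannot say whether the chain length or its double bond counts. A saturated pentyl chain and a shorter ethyl chain at this place would help separate the two.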